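Swapping a hydroxy for a thiadiazolylsulfanyl on two sugar cores

The compounds below may be only part of what the source reports. "The series", "measured", "known", "first", "only" and "open" are said of these compounds alone.

Measured compounds in a functional assay on WiDr cells (Homo sapiens) for antiproliferative activity, read by sulforhodamine B assay, with a stated time of 48 h; a lower number here means a stronger inhibitor of growth, a higher number a weaker inhibitor of growth:
Compound 1 `O=[N+]([O-])c1ccc(-c2nc(CO[C@@H]3O[C@H](CO)[C@H]4OC5(CCCC5)O[C@@H]34)no2)cc1` gives 41000 nM.
Compound 2 `Nc1nnc(SC[C@H]2O[C@@H](OCc3noc(-c4ccc([N+](=O)[O-])cc4)n3)[C@@H]3OC4(CCCC4)O[C@@H]32)s1` gives 26000 nM.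
Compound 3 `CC1(C)O[C@H]2[C@H](OCc3noc(-c4ccc([N+](=O)[O-])cc4)n3)O[C@H](CO)[C@H]2O1` gives only a limit of the assay, > 100000 nM.

Compound 2 differs from compound 1 by (5-amino-1,3,4-thiadiazol-2-yl)sulfanyl in place of hydroxy on a saturated chain carbon bound to a saturated ring carbon. This change gave a 1.6-fold lower number from compound 1 to compound 2 (0.20 log units; within the scatter). Compound 4 `CC1(C)O[C@H]2[C@H](OCc3noc(-c4ccc([N+](=O)[O-])cc4)n3)O[C@H](CSc3nnc(N)s3)[C@H]2O1` carries the same change on the core of compound 3: (5-amino-1,3,4-thiadiazol-2-yl)sulfanyl in place of hydroxy on a saturated chain carbon bound to a saturated ring carbon. How the core of compound 3 differs from that of compound 1 is not broken down here; compound 3 sits at the limit of > 100000 nM in this assay, at which 1 of the 3 values shown sits.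

For compound 4 the expectation is a step of about an at least 1.1-fold lower number from compound 3 to compound 4 (0.04 log units; that floor lies within the scatter) in this assay, resting on the same change having given a 1.6-fold lower number from compound 1 to compound 2 (0.20 log units; within the scatter). Compound 4 is therefore estimated at 90000 nM in this assay, with a range from 40000 nM to 200000 nM, and a real chance that it again returns only a limit.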

Compound 4, concentration for 50% growth inhibition: > 100000 nM
Compound 4: no number, only a limit; the forecaster's own chance of this, stated with the estimate: 50%; middle value at least 1.1-fold (0.04 log units) away from the limit.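

Compound 3 and compound 4 both return only a limit of the assay, so no step between them can be read: the limit of > 100000 nM in this assay, at which 2 of the 4 values shown sit.

As far as these compounds go, whether (5-amino-1,3,4-thiadiazol-2-yl)sulfanyl in place of hydroxy changes growth inhibition on this core remains open in this assay.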